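Azidomethyl for hydroxy on the aminoquinoline chain

This account rests on a few compounds, and the source may have more. Where it says the series, first, only, none or still open, it means among the compounds named here.

Cytotoxicity is followed in an ADME assay on L6 cells (Rattus norvegicus) for cytotoxicity, read by resazurin assay, with a stated time of 70 h; on this read-out lower numbers stand for stronger inhibition and higher numbers for weaker inhibition. Compound 1 `CC(=O)O[C@@H](C(=O)O)[C@@H](NC(=O)c1ccccc1)c1ccccc1` reaches only the assay limit there, > 100000 nM, and that limit is where it sits (the limit of > 100000 nM in this assay, at which 1 of the 2 values shown sits). Compound 2 `OCCNc1ccnc2cc(Cl)ccc12` has no result in this assay, "not determined" (no result reported), so no number places it. Compound 3 `[N-]=[N+]=NCCCNc1ccnc2cc(Cl)ccc12` differs from compound 2 by azidomethyl in place of hydroxy on a saturated chain carbon, two bonds along the chain from a nitrogen on an aromatic ring. Among the measured compounds shown here, with no measured step to lean on, the move from compound 2 to compound 3 in this assay is expected to stay within the scatter rather than shift clearly in either direction. Compound 3 is estimated at 50000 nM in this assay, with a range from 10000 nM to 200000 nM, and a limit-only readout remains likely.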

Compound 3, half-maximal inhibitory concentration: 9480 nM
For compound 3 the middle estimate is 5.3-fold (0.72 log units) above the measured one; the whole stated range lies above it.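

Among the compounds shown here, no step from compound 2 to compound 3 can be read in this assay, where compound 3 gives 9480 nM and compound 2 carries no number. The compounds shown leave open how azidomethyl in place of hydroxy shifts this read-out.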